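The source may hold more compounds than are shown below. What is called first, only, known or untested is meant among the compounds shown, and "the series" means these compounds.

Compound 1 `COc1ccc(Cn2c(=O)n(C3OC(CO)[C@@H](O)[C@H]3O)c3nc(N)nc(O)c32)cc1` is the lower of the two compounds measured in a functional assay on the whole organism with Mus musculus as the target; on this read-out lower numbers stand for smaller maximal responses and higher numbers for larger maximal responses: in this assay compound 1 gives 14%, whereas compound 2 `C=CCn1c(=O)n(C2C[C@H](O)C(CO)O2)c2nc(N)nc(O)c21` reaches 131%, a gap beyond the usual scatter. Compound 3 `Nc1nc(O)c2c(n1)n(C1OC(CO)[C@@H](O)[C@H]1O)c(=O)n2Cc1ccc([N+](=O)[O-])cc1` has not yet been measured; it differs from compound 1 in one place: nitro in place of methoxy on an aromatic carbon. Among the measured compounds shown here, with no measured pair showing this exchange, only a modest step upward or none beyond the scatter is expected, and the step from compound 1 to compound 3 is estimated at a number 16 percentage points higher from compound 1 to compound 3 (beyond the scatter). Compound 3 is therefore expected to give about 30%, ranging from 5% to 90%.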

Compound 3, largest response reached (reported as maximal response), in percent of the reference or control that the assay uses: 16%
Compound 3: the middle estimate sits 14 percentage points above what was measured; the measured number falls inside the stated range.
By their numbers in this assay, from the lowest: compounds 1 and 3 (each within the scatter of the next); then compound 2.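

In this assay, the first exchange read at this position, nitro in place of methoxy on the aromatic carbon para to a large group, gives a step of a number 2 percentage points higher from compound 1 to compound 3 (within the scatter). The read-out therefore does not separate the 4-methoxybenzyl and 4-nitrobenzyl compounds. No measurement at hand offers an explanation for this result. The compounds shown leave open whether an amine or a carboxylic acid on the same carbon would also stay within the scatter of compound 1. They also leave open what a plain benzyl group would give.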